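Branching the ester chain in a shared thiourea-ester series

The compounds below may be only part of what the source reports. "The series", "measured", "known", "first", "only" and "open" are said of these compounds alone.

In an assay on membranes from HEK293 cells for displacement of a labelled ligand from adenosine receptor A2b (Homo sapiens), read by scintillation counting, with a stated time of 30 min, tested at 1 uM (a higher number here means more inhibition at the concentration tested (going by the name of the read-out), a lower number less inhibition), three compounds have been measured:

compound 1 `CCCOC(=O)C1=C(C)NC(=S)NC1c1ccoc1`, 45%
compound 2 `CC1=C(C(=O)OCC(C)C)C(c2ccoc2)NC(=S)N1`, 1%
compound 3 `CCSC(=O)C1=C(C)NC(=O)NC1c1ccco1`, 29%

Compound 2 differs from compound 1 by one change, (methyl in place of hydrogen on a saturated chain carbon bound to two saturated chain carbons). That change gave a number 44 percentage points lower from compound 1 to compound 2 (beyond the scatter). Compound 3 sits between the two in this assay, and the difference between its core and the core of compound 1 is not broken down here.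

Compound 4 `CC1=C(C(=O)SC(C)C)C(c2ccco2)NC(=O)N1` has not yet been measured. It differs from compound 3 by methyl in place of hydrogen on a saturated chain carbon bound to a saturated chain carbon and a sulfur. Among the compounds with values here, this is the same kind of change as the one from compound 1 to compound 2, but the place is not identical: in compound 1 the carbon is bound to two saturated chain carbons, in compound 3 it is bound to a saturated chain carbon and a sulfur. Because the earlier step was a number 44 percentage points lower from compound 1 to compound 2 (beyond the scatter), a loss is expected for compound 4 as well, estimated as a number 21 percentage points lower from compound 3 to compound 4 (beyond the scatter). Compound 4 is therefore expected to give about 8%, in a range from 0% to 25%.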

Compound 4, a percentage reported as inhibition, at one concentration (the size of the read-out at that concentration, not a potency): 22%
The estimate for compound 4 lay 14 percentage points below the measured number; low and high end bracket the measured number.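

In this assay, the methyl that turns ethylsulfanyl into isopropylsulfanyl gave a number 7 percentage points lower from compound 3 to compound 4 (within the scatter), so on this core the added methyl leaves no change that can be told from the scatter. The size of the step therefore did not carry over from one core to the other: the same change on two cores in this assay, a number 44 percentage points lower (beyond the scatter) from compound 1 to compound 2 and a number 7 percentage points lower (within the scatter) from compound 3 to compound 4, 37 percentage points apart, beyond the scatter of two such steps. This does not show which difference between the two pairs matters, as the carbon taking the methyl is bound to two saturated chain carbons in one pair and to a saturated chain carbon and a sulfur in the other, the cores differ as well, and two pairs cannot separate these differences or give a general rule.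

The compounds shown leave open how the number responds at this place to a longer chain, such as butyl, or to a chain ending in an amine. They also leave open how large the methyl step would be on a core that differs from the core of compound 3 in only one place.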